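The source may report more compounds than this note shows. Statements on the series, on what has been measured and on what is new or still open speak of the compounds shown alone.

Within the data shown here, compound 1 `COc1ccc(NS(=O)(=O)c2ccc(N3CCNC3=O)cc2)cc1` is the only compound here with a number: in a functional assay on M21 cells (Homo sapiens) for antiproliferative activity, read by sulforhodamine B assay, with a stated time of 48 h (on this read-out higher numbers stand for weaker inhibition and lower numbers for stronger inhibition), compound 1 gives 580 nM. Compound 2 `CC(C)Cc1ccc(NS(=O)(=O)c2ccc(N3CCNC3=O)cc2)cc1` gives in this assay only a limit, > 1000 nM. Among the measured compounds shown here, the one measured step, an at least 1.7-fold higher number from compound 1 to compound 2 (0.23 log units; that floor lies within the scatter), rests on that limit of > 1000 nM in this assay, at which 1 of the 2 values shown sits, and concerns isobutyl in place of methoxy, not the change at hand. Compound 3 `COc1ccc(NS(=O)(=O)c2ccc(N3CCNC3=O)cc2)cc1OC` differs from compound 1 by methoxy in place of hydrogen on an aromatic carbon. For the measured compounds named here, no measured step bears on this change, so for compound 3 the expected step is a 1.0-fold higher number from compound 1 to compound 3 (0.01 log units; within the scatter), none beyond the scatter. Compound 3 is estimated at 600 nM, between 250 nM and 1500 nM.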

Compound 3, half-maximal inhibitory concentration: 340 nM
The estimate for compound 3 lay 1.8-fold (0.25 log units) above the measured number, within the range that was stated.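

Methoxy in place of hydrogen on this aromatic carbon, ortho to a methoxy group and meta to a large group, gives in this assay a 1.7-fold lower number from compound 1 to compound 3 (0.23 log units; within the scatter). Among these compounds, this is the first reading at this position, and the added methoxy brings no step beyond the scatter. Unlike the step to compound 2, this one joins two numbers and does not rest on a limit: the limit of > 1000 nM in this assay, at which 1 of the 3 values shown sits.

The compounds shown leave open whether a fluorine, a hydroxyl or an amine on this carbon would give a step beyond the scatter. They also leave open whether a longer chain on the oxygen would do so.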